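This account rests on a few compounds, and the source may have more. Where it says the series, first, only, none or still open, it means among the compounds named here.

The measured compounds:

Compound 1, `NCCCCCOc1ccc([C@H]2CC[C@]3(CC2)OOC2(O3)C3CC4CC(C3)CC2C4)cc1`: in an ADME assay on microsomes from liver (Homo sapiens) for metabolic stability, read by LC-MS, tested at 1 uM (a higher number here means faster removal of the compound, a lower number slower removal), compound 1 gives < 7 mL.min-1.g-1, which is a limit of the assay and not a number.
Compound 2, `OC1(COc2ccc([C@H]3CC[C@]4(CC3)OOC3(O4)C4CC5CC(C4)CC3C5)cc2)CCNCC1`: in this assay compound 2 gives 16 mL.min-1.g-1.
Compound 3, `CC(C)(N)CCOc1ccc([C@H]2CC[C@]3(CC2)OOC2(O3)C3CC4CC(C3)CC2C4)cc1`: in this assay compound 3 gives < 7 mL.min-1.g-1, which again is a limit of the assay.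

Compound 2 is thus the only one of the three that gives a number in this assay; the other two sit at the limit of < 7 mL.min-1.g-1 in this assay, at which 2 of the 3 values shown sit.

The unmeasured compound 4, `NCCCCOc1ccc([C@H]2CC[C@]3(CC2)OOC2(O3)C3CC4CC(C3)CC2C4)cc1`, differs from compound 2 in one place: 3-aminopropyl in place of 4-hydroxypiperidin-4-yl on a saturated chain carbon bound to an oxygen on an aromatic ring.

For the measured compounds named here, two measured steps bear on this change. The first is an at least 2.2-fold higher number from compound 1 to compound 2 (0.35 log units; beyond the scatter), the second is an at least 2.2-fold lower number from compound 2 to compound 3 (0.35 log units; beyond the scatter). Both steps run between the number for compound 2 and a limit, so their exact size is not readable, yet both show that removing the 4-hydroxypiperidin-4-yl group from this position lowers the number at least modestly. The step from compound 1 to compound 3 is a step that the two limits leave unreadable from compound 1 to compound 3.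

For compound 4, the estimated step is therefore a 3.2-fold lower number from compound 2 to compound 4 (0.51 log units; beyond the scatter), in the same direction as the two measured steps. Compound 4 is accordingly expected to give about 5 mL.min-1.g-1, within a range from 3 mL.min-1.g-1 to 11 mL.min-1.g-1, most likely reported only as a limit.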

Compound 4, intrinsic clearance in microsomes: < 7 mL.min-1.g-1
Compound 4 gave a limit, no number; the forecaster's own chance of this, stated with the estimate: 70%; the middle value is on the limit's open side.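

Placing 3-aminopropyl in place of 4-hydroxypiperidin-4-yl, on a saturated chain carbon bound to an oxygen on an aromatic ring, gives an at least 2.2-fold lower number from compound 2 to compound 4 (0.35 log units; beyond the scatter) in this assay. With 3-aminopropyl alongside the open-chain amines of compound 1 and compound 3, all three compounds with such a chain at this position now fall on the same side of compound 2, which alone carries the ring and alone gives a number. The steps among compound 1, compound 3 and compound 4 cannot be read, and the three chains cannot be placed in any order, since all three values sit at one limit: the limit of < 7 mL.min-1.g-1 in this assay, at which 3 of the 4 values shown sit.

The compounds shown leave open whether the higher number of compound 2 goes with the six-membered ring or with its hydroxyl group, as the two leave together in every step; a plain piperidin-4-yl group, or a hydroxyl group on an open amine chain, would separate them. They also leave open how far the three open-chain amines lie from one another beyond the limit, and whether a carboxylic acid or an amide in place of the amine would stay at that limit.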